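Three cytotoxicity limits and one compound still to measure

The compounds below may be only part of what the source reports. "The series", "measured", "known", "first", "only" and "open" are said of these compounds alone.

Compound 1 `CC(C)N(Cc1cccc(OCCCCCC(=O)O)c1)C(=O)c1ccc(-c2ccc3[nH]ccc3c2)cc1` carries the 1H-indol-5-yl group and a free carboxylic acid at the end of its chain. In an ADME assay on Raji cells (Homo sapiens) for cytotoxicity, read by CellTiter-Glo and resazurin assay, with a stated time of 72 h (a lower number here means that less compound is needed, a higher number that more compound is needed for the effect), compound 1 gives only a limit of the assay, > 26000 nM. Compound 2 `CCOc1cccc(-c2ccc(C(=O)N(Cc3cccc(OCCCCCC(=O)O)c3)C(C)C)cc2)c1` differs from it by 3-ethoxyphenyl in place of 1H-indol-5-yl on an aromatic carbon. In this assay compound 2 likewise gives only a limit, > 20800 nM. Between the two there is a step that the two limits leave unreadable from compound 1 to compound 2. Compound 3 `CCOC(=O)CCCCCOc1cccc(CN(C(=O)c2ccc(-c3ccc4[nH]ccc4c3)cc2)C(C)C)c1` keeps the 1H-indol-5-yl group but differs from compound 1 by ethyl in place of hydrogen on an oxygen next to a carbonyl group; this is how the core of compound 3 differs from the core of compound 1. In this assay compound 3 gives only a limit, > 26000 nM. Between compound 1 and compound 3 there is a step that the two limits leave unreadable from compound 1 to compound 3.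

Compound 4 `CCOC(=O)CCCCCOc1cccc(CN(C(=O)c2ccc(-c3cccc(OCC)c3)cc2)C(C)C)c1` has not yet been measured. Among the compounds with values here, it differs from compound 3 by 3-ethoxyphenyl in place of 1H-indol-5-yl on an aromatic carbon, the same change as the one from compound 1 to compound 2, made at the same place. For compound 4 in this assay the expected step that the limit leaves unreadable from compound 3 to compound 4 stands beside the measured one as an expectation without a numerical anchor, because the limit of > 26000 nM in this assay, at which 2 of the 3 values shown sit, carries two of the three values and the limit of > 20800 nM in this assay, at which 1 of the 3 values shown sits, the third, so no number exists to move from. Compound 4 is therefore expected near 40000 nM, most probably reported again only as a limit, with a range from 15000 nM to 150000 nM covering it.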

Compound 4, half-maximal effective concentration: > 22300 nM
Compound 4 gave a limit, no number; the forecaster's own chance of this, stated with the estimate: 85%; the middle value does not contradict the limit.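

In this assay compound 4 gives only a limit of the assay, > 22300 nM. The steps to compound 4 from compound 3 and from compound 2 cannot be read, since each of these compounds has a limit and no number. The compounds shown leave open at what concentration compound 1, compound 2, compound 3 or compound 4 would reach the half-maximal effect, and whether either change shifts that concentration.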